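From 3-Fluoro-4-methoxyphenyl to Phenyl in Compound 4

The source may report more compounds than this note shows. Statements on the series, on what has been measured and on what is new or still open speak of the compounds shown alone.

Of the compounds shown here, three sharing one core have been tested in a functional assay on SGC-7901 cells (Homo sapiens) for antiproliferative activity, read by MTT assay, with a stated time of 72 h; a higher number here means a weaker inhibitor, a lower number a stronger inhibitor. Compound 1 `COc1cc(-n2cnc3ccc(-c4ccccc4Cl)cc32)cc(OC)c1OC` gives > 10000 nM, which is a limit of the assay and not a number. Compound 2 `COc1cc(-n2cnc3ccc(-c4ccc(C)cc4F)cc32)cc(OC)c1OC` gives 5650 nM. Compound 3 `COc1ccc(-c2ccc3ncn(-c4cc(OC)c(OC)c(OC)c4)c3c2)cc1F` gives 430 nM, the lowest number of the three. The data show a 13-fold lower number from compound 2 to compound 3 (1.12 log units; beyond the scatter) and an at least 23-fold lower number from compound 1 to compound 3 (1.36 log units; beyond the scatter), both large, whereas the remaining comparison gives only an at least 1.7-fold lower number from compound 1 to compound 2 (0.24 log units; that floor lies within the scatter).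

Compound 4 `COc1cc(-n2cnc3ccc(-c4ccccc4)cc32)cc(OC)c1OC` has not yet been measured. It differs from compound 3 by phenyl in place of 3-fluoro-4-methoxyphenyl on an aromatic carbon, with phenyl in place of 3-fluoro-4-methoxyphenyl on an aromatic carbon. Within the data shown here, no tested compound carries phenyl, so the two large steps that end at compound 3 are the closest guide, read in reverse. Neither of the compounds without 3-fluoro-4-methoxyphenyl comes close to compound 3, so a large step towards a weaker inhibitor is expected, estimated as a 7.0-fold higher number from compound 3 to compound 4 (0.84 log units; beyond the scatter). In this assay, the expected value for compound 4 is 3000 nM, with an estimated range from 700 nM to 10000 nM.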

Compound 4, half-maximal inhibitory concentration: 290 nM
Compound 4: middle estimate off by 10-fold (1.01 log units), on the high side; measured number below the stated range.
By their numbers in this assay, from the lowest: compounds 4 and 3 (each within the scatter of the next); then compound 2. At a limit, above all of these: compound 1.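

In this assay the 3-fluoro-4-methoxyphenyl group turns out not to be needed at this position, since its replacement by plain phenyl gives a 1.5-fold lower number from compound 3 to compound 4 (0.17 log units; within the scatter) and the two compounds cannot be told apart. The earlier gap therefore did not show a gain from that group: phenyl also stands well clear of 2-fluoro-4-methylphenyl, with a 19-fold lower number from compound 2 to compound 4 (1.29 log units; beyond the scatter) in this single change. Compound 1 stands at a limit of the assay and not at a number, so its comparison, an at least 34-fold lower number from compound 1 to compound 4 (1.53 log units; beyond the scatter) with hydrogen in place of chloro, gives only a floor: the limit of > 10000 nM in this assay, at which 1 of the 4 values shown sits.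

The compounds shown leave open whether phenyl carrying only a 4-methoxy group or only a 3-fluoro group would stay level with compound 4. They also leave open how a pyridine ring or an aminophenyl group would fare at this position.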